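This account rests on a few compounds, and the source may have more. Where it says the series, first, only, none or still open, it means among the compounds named here.

For the measured compounds named here, compound 1, `O=C(COc1ccc(CNC2CC=C(c3c[nH]c4cccc(F)c34)CC2)c(F)c1)NO`, is the stronger of the two compounds measured so far. In a functional assay on SW480 cells (Homo sapiens) for antiproliferative activity, with a stated time of 72 h (a lower number here means a stronger inhibitor, a higher number a weaker inhibitor), compound 1 gives 189 nM. Going by the values given here, the only other measured compound, compound 2, `O=C(COc1ccc(C(=O)N2CC=C(c3c[nH]c4cccc(F)c34)CC2)cc1)NO`, carries an amide linker in place of the secondary amine and lacks the fluoro on the benzyl ring; in this assay compound 2 gives 1490 nM, a markedly higher number, well beyond the usual scatter. Compound 1 therefore stands at the lowest number of the pair.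

Compound 3, `O=C(COc1ccc(CNC2CC=C(c3c[nH]c4ccccc34)CC2)c(F)c1)NO`, has not yet been measured. It differs from compound 1 only in one place: hydrogen in place of fluoro on an aromatic carbon. Among the compounds with values here, no step between two measured compounds shows what this change does on its own, so any expectation rests on the size of the change, which is a single heavy atom leaving the core and nothing else moving. For that reason the step from compound 1 to compound 3 is expected to be small, most likely a slight weakening, and quite possibly within the scatter, a 1.5-fold higher number from compound 1 to compound 3 (0.17 log units; within the scatter). Compound 3 is estimated to give 280 nM in this assay, with a plausible range from 110 nM to 700 nM.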

Compound 3, half-maximal inhibitory concentration: 1150 nM
The estimate for compound 3 lay 4.1-fold (0.61 log units) below the measured number, outside the stated range (above it).
By their numbers in this assay, from the lowest: compound 1; then compounds 3 and 2 (each within the scatter of the next).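

In this assay, the step from the 4-fluoro-1H-indol-3-yl group to the 1H-indol-3-yl group gives a 6.1-fold higher number from compound 1 to compound 3 (0.78 log units; beyond the scatter) and so isolates the contribution of a single fluoro on an aromatic carbon, ortho to a fused ring and meta to a fused ring. Compounds 1 and 2 differ in more than one place and could not show this, whereas here one heavy atom is the only structural difference, and the step lies beyond the scatter, so this position is not indifferent to the change from fluoro to hydrogen. Nothing on hand accounts for the size of this step, and the data give no measured property that could explain it.

The compounds shown leave open whether the lower number is particular to fluoro or would also follow from a chlorine, a methoxy group or a nitrile on the same carbon. They also leave open how the amine linker and the second fluoro of compound 1 each contribute on their own, and whether a fluoro on another carbon of this ring would give a similar number.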